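The source may hold more compounds than are shown below. What is called first, only, known or untested is meant among the compounds shown, and "the series" means these compounds.

Measured compounds:
Compound 1, `Nc1ccccc1NC(=O)c1ccc(NC(=S)NCc2ccc(Cl)nc2)cc1`: in an assay on isolated protein for inhibition of Nicotinamide phosphoribosyltransferase (Homo sapiens), read by fluorescence, with stated times of 5 min and 15 min (a higher number here means a weaker inhibitor, a lower number a stronger inhibitor), compound 1 gives > 2000 nM.
Compound 2, `Nc1ccccc1NC(=O)c1ccc(CNC(=O)c2cc3cnccc3[nH]2)cc1`: in this assay compound 2 gives > 2000 nM.

The value of compound 1 is a limit of the assay, not a number. The value of compound 2 is likewise a limit. Compound 1 therefore stands at the limit of > 2000 nM in this assay, at which 2 of the 2 values shown sit, so no order among the measured compounds can be read. Compound 3, `Nc1ccccc1NC(=O)c1ccc(NC(=S)NCc2cccc(Cl)c2)cc1`, differs from compound 1 by 3-chlorophenyl in place of 6-chloropyridin-3-yl on a saturated chain carbon bound to an amide-type nitrogen. With both measured values resting at a limit, no step beyond the scatter can be drawn from them, and the expected step in this assay is a step that the limit leaves unreadable from compound 1 to compound 3, most likely reported once more as a limit. Compound 3 is expected to give about 3500 nM, within 1500 nM to 12000 nM.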

Compound 3, half-maximal inhibitory concentration: > 2000 nM
Compound 3: only a limit was reported (the forecaster's own chance of this, stated with the estimate: 80%); the middle value lies beyond the limit too.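

Compound 3, like compound 1, rests at a limit of this assay, so no step can be read between them: the limit of > 2000 nM in this assay, at which 3 of the 3 values shown sit. The compounds shown leave open how strongly each one actually inhibits, and whether 3-chlorophenyl or 6-chloropyridin-3-yl is the better group.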